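A few compounds are considered here, and "the series" means these few. Any claim that something is new, unique, unknown or untested is made for them only; others in the source may bear on it.

Working notes on the series, followed in a functional assay on A549 cells (Homo sapiens) for cytotoxicity, read by MTT assay, with a stated time of 24 h; on this read-out higher numbers stand for weaker inhibition and lower numbers for stronger inhibition. Compound 1 (`C/C(=N\NC(=O)/C(C#N)=C/c1ccccc1)c1c(O)c2ccc(O)cc2oc1=O`) gives 14800 nM. Within the data shown here, compound 2 (`C/C(=N\NC(=O)/C(C#N)=C/c1ccc(O)cc1)c1c(O)c2ccc(O)cc2oc1=O`) gives 6230 nM, the lower of the two numbers measured so far. Among the measured compounds shown here, the only measured step is a 2.4-fold lower number from compound 1 to compound 2 (0.38 log units; beyond the scatter), a modest change beyond the scatter, made by hydroxy in place of hydrogen on an aromatic carbon.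

Compound 3 (`COc1cc(/C=C(\C#N)C(=O)N/N=C(\C)c2c(O)c3ccc(O)cc3oc2=O)ccc1O`) is the next to be read. Its change is methoxy in place of hydrogen on an aromatic carbon, ortho to a hydroxy group and meta to a large group, taking 4-hydroxyphenyl to 4-hydroxy-3-methoxyphenyl. For the measured compounds named here, no measured step tests methoxy, so the direction is open. The nearest guide is a 2.4-fold lower number from compound 1 to compound 2 (0.38 log units; beyond the scatter), a substitution on the same aromatic ring, and it sets only a rough scale. In this assay, no shift beyond the scatter is therefore expected, though one of that modest size in either direction would not surprise. The expected change is a 1.1-fold lower number from compound 2 to compound 3 (0.05 log units; within the scatter). The estimated value for compound 3 is 5500 nM, with an expected range of 2200 nM to 13000 nM.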

Compound 3, half-maximal inhibitory concentration: 12600 nM
For compound 3 the middle estimate is 2.3-fold (0.36 log units) below the measured one; the measured number falls inside the stated range.
By their numbers in this assay, from the lowest: compound 2; then compounds 3 and 1 (each within the scatter of the next).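

In this assay the methoxy group, placed ortho to a hydroxy group and meta to a large group, moves the number the other way from the earlier hydroxy change: a 2.0-fold higher number from compound 2 to compound 3 (0.31 log units; beyond the scatter) stands against a 2.4-fold lower number from compound 1 to compound 2 (0.38 log units; beyond the scatter) on the same aromatic ring. Substitution on this ring can therefore raise the number as well as lower it, so the advantage of compound 2 over compound 1 does not carry over to every further group added to the 4-hydroxyphenyl ring. Read directly against the unsubstituted phenyl, 4-hydroxy-3-methoxyphenyl gives a 1.2-fold lower number from compound 1 to compound 3 (0.07 log units; within the scatter) and so sits within the scatter of compound 1, which leaves compound 2 alone with a number lower than the other two. The data at hand offer no explanation for this reversal.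

Still open, on these data alone, is whether the higher number of compound 3 is specific to methoxy or would also appear with a fluorine, a hydroxy or an amine on the same aromatic carbon. Also open, as far as these compounds go, is how a longer chain such as ethoxy would read there, and whether methoxy would give a similar step on the phenyl ring of compound 1, without the hydroxy group.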